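The compounds below may be only part of what the source reports. "The series", "measured", "known", "first", "only" and "open" are said of these compounds alone.

Measured in an ADME assay on MT4 cells (Homo sapiens) for cytotoxicity, read by MTT assay, with a stated time of 4 days; a higher number here means that more compound is tolerated, a lower number that less compound is tolerated:
compound 1 `COc1ccc(Oc2nc(Nc3ccc(C#N)cc3)nc3ccccc23)cc1` gives 340000 nM;
compound 2 `N#Cc1ccc(Nc2nc(Oc3ccc(Cl)cc3Cl)c3ccccc3n2)cc1` gives 32000 nM;
compound 3 `Cc1ccccc1Oc1nc(Nc2ccc(C#N)cc2)nc2ccccc12` gives 355000 nM.

Compound 1 stands second highest of the three in this assay; its nearest neighbour is compound 3, the step being a 1.0-fold higher number from compound 1 to compound 3 (0.02 log units; within the scatter), while the furthest is compound 2, with an 11-fold lower number from compound 1 to compound 2 (1.03 log units; beyond the scatter).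

Compound 4 `Cc1cccc(Oc2nc(Nc3ccc(C#N)cc3)nc3ccccc23)c1` differs from compound 1 by 3-methylphenyl in place of 4-methoxyphenyl on an oxygen on an aromatic ring. The step that bears most directly on this change is a 1.0-fold higher number from compound 1 to compound 3 (0.02 log units; within the scatter), where a methylphenyl likewise replaced the 4-methoxyphenyl and the number did not move beyond the scatter. The large steps, an 11-fold lower number from compound 1 to compound 2 (1.03 log units; beyond the scatter) and an 11-fold higher number from compound 2 to compound 3 (1.05 log units; beyond the scatter), both involve the 2,4-dichlorophenyl, which does not enter here. No step beyond the scatter is therefore expected in this assay for compound 4.

Compound 4 is estimated at 340000 nM, with a range of 160000 nM to 700000 nM, which is expected to mean a step of no change at the digits printed from compound 1 to compound 4 (within the scatter).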

Compound 4, half-maximal cytotoxic concentration: 355000 nM
The estimate for compound 4 lay 1.0-fold (0.02 log units) below the measured number; low and high end bracket the measured number.
By their numbers in this assay, from the lowest: compound 2; then compounds 1, 3 and 4 (each within the scatter of the next).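

In this assay, the 3-methylphenyl on this oxygen reads the same as the 2-methylphenyl (no change at the digits printed from compound 3 to compound 4 (within the scatter)) and the 4-methoxyphenyl (a 1.0-fold higher number from compound 1 to compound 4 (0.02 log units; within the scatter)), so these three groups are not told apart here. Among these compounds, the 2,4-dichlorophenyl stays the only group set apart (an 11-fold higher number from compound 2 to compound 4 (1.05 log units; beyond the scatter)). Nothing at hand explains that gap. Going by these compounds, it remains open whether a single chlorine in this place would go with compound 2 or with compound 1, compound 3 and compound 4, and how an amine or a carboxylic acid would read.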